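The source may report more compounds than this note shows. Statements on the series, on what has been measured and on what is new or still open speak of the compounds shown alone.

Compound 1 `O=C(C1CCCCC1)N1N=CCC1c1ccccc1` stands highest of the two compounds measured in a physicochemical assay for lipophilicity, read by HPLC, measured as chromatographic lipophilicity, at pH 7.4 (a lower number here means a more polar compound, a higher number a more lipophilic compound), where compound 1 gives 5.9. Its nearest neighbour, compound 2 `Cc1nnc(N2CCC(C(=O)N3N=CC[C@H]3c3cc(F)cc(F)c3)CC2)o1`, sits well apart: in this assay compound 2 gives 3.6, a gap beyond the usual scatter. The unmeasured compound 3 `O=C(c1ccncc1)N1N=CCC1c1ccccc1` differs from compound 1 in one place, (pyridin-4-yl in place of cyclohexyl on a carbonyl carbon). For the measured compounds named here, no measured pair shows this change, so its size is an expectation only. A large downward step in this assay is expected, a number 2.70 log units lower from compound 1 to compound 3 (beyond the scatter). Compound 3 is accordingly estimated at 3.2, within a range from 2.5 to 3.9.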

Compound 3, distribution coefficient: 2.7
Compound 3: middle estimate off by 0.50 log units, on the high side; low and high end bracket the measured number.
By their numbers in this assay, from the lowest: compound 3; then compound 2; then compound 1.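

At this position, on a carbonyl carbon whose other neighbours are an amide-type nitrogen in a ring, the swap of cyclohexyl for pyridin-4-yl now has a measured size in this assay (a number 3.20 log units lower from compound 1 to compound 3 (beyond the scatter)). The two groups match in heavy-atom count, so this large step comes with no change in that count. No measurement available here explains the step. As far as these compounds go, whether phenyl or pyridin-3-yl on the same carbonyl carbon would give a step of similar size remains open. So does whether this step would carry over to other cores.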